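The source may report more compounds than this note shows. Statements on the series, on what has been measured and on what is new or still open speak of the compounds shown alone.

Measured compounds in a functional assay on K562 cells (Homo sapiens), read by MTT assay, with a stated time of 72 h; on this read-out higher numbers stand for weaker inhibition and lower numbers for stronger inhibition: compound 1 `COc1ncnc2c1c(-c1ccoc1)cn2[C@@H]1O[C@H](CO)[C@@H](O)[C@H]1O` gives 190 nM; compound 2 `Cc1ncnc2c1c(-c1ccoc1)cn2[C@@H]1O[C@H](CO)[C@@H](O)[C@H]1O` gives > 20000 nM; compound 3 `CNc1ncnc2c1c(-c1cccs1)cn2[C@@H]1O[C@H](CO)[C@@H](O)[C@H]1O` gives > 20000 nM.

Compound 3 stands at the limit of > 20000 nM in this assay, at which 2 of the 3 values shown sit, a limit rather than a number. Compound 2 also sits at that limit. For the measured compounds named here, compound 1 is the only one of the three with a number, and the single measured step, an at least 100-fold higher number from compound 1 to compound 2 (2.02 log units; beyond the scatter), is large and beyond the scatter.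

The step now followed leads from compound 3 to compound 4 `CNc1ncnc2c1c(-c1ccoc1)cn2[C@@H]1O[C@H](CO)[C@@H](O)[C@H]1O`, through (furan-3-yl in place of thiophen-2-yl on an aromatic carbon). Going by the values given here, none of the measured steps concerns this change: the one measured step swaps methyl for methoxy on an aromatic carbon and leaves the five-membered ring untouched, so it gives no direct guide to the size or direction of the present step in this assay. What can be said is that compound 1, which carries furan-3-yl, gives a number in this assay, whereas compound 3, with thiophen-2-yl and methylamino, only reaches the limit. Compound 4 combines methylamino with furan-3-yl, and the two values shown for compound 1 and compound 3 do not separate the two changes. Compound 4 is therefore expected to come in somewhere between the two, at an estimated 4000 nM (from 300 nM to 20000 nM), which would mean an expected step of an at least 5.0-fold lower number from compound 3 to compound 4 (0.69 log units; beyond the scatter).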

Compound 4, half-maximal inhibitory concentration: > 20000 nM
Compound 4 ended at the assay's limit (the forecaster's own chance of this, stated with the estimate: 35%); middle value at least 5.0-fold (0.69 log units) from the limit.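

With furan-3-yl held fixed on the core, the group on the other aromatic carbon can now be judged on its own in this assay: methylamino in place of methoxy gives an at least 100-fold higher number from compound 1 to compound 4 (2.02 log units; beyond the scatter). Set beside the earlier change of methoxy to methyl, which gave an at least 100-fold higher number from compound 1 to compound 2 (2.02 log units; beyond the scatter), this shows that furan-3-yl alone does not secure a measurable number, and that among the compounds shown only the methoxy compound has one. The steps to compound 4 from compound 2 and from compound 3 cannot be read, so the change from thiophen-2-yl to furan-3-yl remains without a size, as both ends of each step sit at the same limit: the limit of > 20000 nM in this assay, at which 3 of the 4 values shown sit.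

The compounds shown leave open whether thiophen-2-yl and furan-3-yl would differ at all on a core carrying methoxy, where a number could be read. From the compounds shown here alone, it also remains open whether an ethoxy group, an unsubstituted amine or a chlorine atom on that aromatic carbon would give a value close to that of compound 1, which gives 190 nM.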